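Carbamate to ethylpyrimidinyl on the ring nitrogen of compound 2

The compounds below may be only part of what the source reports. "The series", "measured", "known", "first", "only" and "open" are said of these compounds alone.

Measured compounds:
compound 1, `CC(C)COC(=O)N1CCC(n2ncc3cc(-c4ccc(S(C)(=O)=O)cc4)ncc32)CC1`, 11 nM
compound 2, `CC(C)(OC(=O)N1CCC(n2ncc3cc(-c4ccc(S(C)(=O)=O)cc4)ncc32)CC1)C(F)F`, 23 nM

Both compounds were tested in a functional assay on HEK293 cells for agonist activity at Glucose-dependent insulinotropic receptor (Homo sapiens), read by cAMP accumulation, with a stated time of 30 min; on this read-out higher numbers stand for an effect only at larger amounts of compound and lower numbers for an effect already at smaller amounts. Compound 2 gives 23 nM, which is the higher of the two numbers; compound 1 gives 11 nM. For the measured compounds named here, the one step between them, a 2.1-fold higher number from compound 1 to compound 2 (0.32 log units; beyond the scatter), exchanges one group on the oxygen of the carbamate for another and moves the number modestly.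

Compound 3, `CCc1cnc(N2CCC(n3ncc4cc(-c5ccc(S(C)(=O)=O)cc5)ncc43)CC2)nc1`, has not yet been measured. It differs from compound 2 as follows: 5-ethylpyrimidin-2-yl in place of (1-(difluoromethyl)-1-methylethoxy)carbonyl on an amine nitrogen in a ring. Going by the values given here, this change removes the whole carbamate rather than exchanging a group on its oxygen, so no measured step addresses it directly. Among the compounds with values here, the only step known at this region, from compound 1 to compound 2, was modest, which shows that the site tolerates some variation but says nothing about a group of a different kind. The direction of the step in this assay is therefore open, and a change of modest size either way is expected, with a 1.2-fold lower number from compound 2 to compound 3 (0.06 log units; within the scatter) as the estimate. For compound 3 the expected value in this assay is 20 nM, within a range from 5 nM to 80 nM.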

Compound 3, half-maximal effective concentration: 13 nM
Compound 3: the middle estimate sits 1.5-fold (0.19 log units) above what was measured; measured number inside the range.
By their numbers in this assay, from the lowest: compounds 1, 3 and 2 (each within the scatter of the next, the first and the last beyond it).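

Replacing the carbamate on the amine nitrogen in a ring with 5-ethylpyrimidin-2-yl gives a 1.8-fold lower number from compound 2 to compound 3 (0.25 log units; within the scatter) in this assay and a 1.2-fold higher number from compound 1 to compound 3 (0.07 log units; within the scatter) on the same read-out, so neither carbamate stands apart from compound 3. For the compounds shown here, until now this position had been seen only with carbamates that differ on their oxygen; compound 3 shows that a group with no carbonyl, built on a six-membered aromatic ring with 2 hetero atoms, can take the place of the whole carbamate and still give a number within the scatter of both. The carbamate as such is therefore not required for a number of this size in this assay, although nothing available here explains why the two kinds of group give such similar numbers.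

As far as these compounds go, it remains open what the ethyl group contributes to compound 3, and what a methyl group, a propyl chain or a methoxy group would give in its place on the pyrimidine. Also open, from the compounds shown here alone, is how an amide or a urea on the same ring nitrogen, or a pyridine ring in place of the pyrimidine, would compare with these three compounds.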